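Lengthening the nitrile chain of compound 3

The compounds below may be only part of what the source reports. "The series", "measured", "known", "first", "only" and "open" are said of these compounds alone.

Compound 1 `CCCn1cnc2c1c(=O)n(C)c(=O)n2CCC` gives 5000 nM
Compound 2 `C=CCCn1cnc2c1c(=O)n(C)c(=O)n2CCC` gives 16800 nM
Compound 3 `CCCn1c(=O)n(C)c(=O)c2c1ncn2CC#N` gives 35300 nM

In a functional assay (trachea) with Cavia porcellus as the target (a higher number here means that more compound is needed for the effect, a lower number that less compound is needed), compound 3 stands highest of the three at 35300 nM and so needs the most compound for the effect. The smaller gap to it is a 2.1-fold higher number from compound 2 to compound 3 (0.32 log units; beyond the scatter) and the larger is a 7.1-fold higher number from compound 1 to compound 3 (0.85 log units; beyond the scatter) on the same scale.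

Compound 4 `CCCn1c(=O)n(C)c(=O)c2c1ncn2CCC#N` is still unmeasured. It has cyanomethyl in place of cyano on a saturated chain carbon bound to an aromatic nitrogen and so reads as cyanomethyl to 2-cyanoethyl. Going by the values given here, no measured step shows this exact change. The two gaps above bear on it most closely. Each put cyano on that chain carbon, where compound 1 has ethyl and compound 2 has allyl, and each ended at a higher number. Compound 4 carries cyanomethyl there instead, so part of those gaps may close. Still, a 3.4-fold higher number from compound 1 to compound 2 (0.53 log units; beyond the scatter) shows a rise without any nitrile, so only a modest step to a lower number is expected. The expected step is a 2.1-fold lower number from compound 3 to compound 4 (0.32 log units; beyond the scatter) in this assay by this estimate. For compound 4 the estimated value is 17000 nM with an expected range from 7000 nM to 40000 nM in this estimate.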

Compound 4, half-maximal effective concentration: 27600 nM
The estimate for compound 4 lay 1.6-fold (0.21 log units) below the measured number; low and high end bracket the measured number.
By their numbers in this assay, from the lowest: compound 1; then compounds 2, 4 and 3 (each within the scatter of the next, the first and the last beyond it).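

In this assay, moving from cyanomethyl to 2-cyanoethyl on a saturated chain carbon bound to an aromatic nitrogen gives a 1.3-fold lower number from compound 3 to compound 4 (0.11 log units; within the scatter), so this extension of the nitrile chain makes no readable difference. The other two steps show where the longer nitrile stands: a 1.6-fold higher number from compound 2 to compound 4 (0.22 log units; within the scatter) cannot be read as a difference either, whereas a 5.5-fold higher number from compound 1 to compound 4 (0.74 log units; beyond the scatter) shows that the gap to compound 1 remains at this chain length. Nothing available explains these results.

The compounds shown leave open whether a still longer nitrile chain would behave the same way. They also leave open whether an amine or a carboxylic acid at the end of this chain would come closer to compound 1, at 5000 nM.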